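A few compounds are considered here, and "the series" means these few. Any claim that something is new, unique, unknown or untested is made for them only; others in the source may bear on it.

Compound 1 `O=C(/C=C/c1ccncc1-c1ccc2[nH]ccc2c1)N1CCOCC1` carries a morpholine amide on its core, and in an assay on a protein complex for inhibition of CDK8/Cyclin C (Homo sapiens), with a stated time of 1 h, tested at 10 uM (on this read-out lower numbers stand for less inhibition and higher numbers for more inhibition at the one concentration tested (going by the name of the read-out)), compound 1 gives 97%. Compound 2 `Cn1ccc2cc(-c3cnccc3/C=C/C(=O)N3CCOCC3)ccc21` gives 97% in this assay, so the step of no change at the digits printed from compound 1 to compound 2 (within the scatter) shows no movement. Compound 3 `O=C(/C=C/c1ccncc1-c1ccc2ccccc2c1)N1CCOCC1` gives 99% in this assay. Compound 1 thus stands level with compound 2, the two together at the lower end of the three numbers, and the value of compound 3 lies within the scatter of compound 1, so all three sit near the top of the read-out.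

Compound 4 `CNC(=O)/C=C/c1ccncc1-c1ccc2[nH]ccc2c1` differs from compound 1 in one place: methylamino in place of morpholin-4-yl on a carbonyl carbon. Among the measured compounds shown here, no measured step touches this part of the molecule; the one step known, from compound 1 to compound 2, concerns a different place and stayed within the scatter, so it gives no guidance on the amide itself. With compound 1 already near the ceiling, little room remains upward, and the expectation is a small loss or none, estimated as a number 12 percentage points lower from compound 1 to compound 4 (beyond the scatter). Compound 4 is therefore expected to give 85%, with a range from 60% to 99%.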

Compound 4, a percentage reported as inhibition, at one concentration (the size of the read-out at that concentration, not a potency): 100%
Compound 4: the middle estimate sits 15 percentage points below what was measured; measured number above the stated range.
By their numbers in this assay, from the lowest: compounds 1, 2, 3 and 4 (each within the scatter of the next).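

Replacing morpholin-4-yl on the carbonyl carbon with methylamino cuts the group from 6 heavy atoms to 2, removes the ring and adds a hydrogen-bond donor, and in this assay the result is a number 3 percentage points higher from compound 1 to compound 4 (within the scatter). Among the compounds shown here, the morpholin-4-yl ring is therefore not needed to keep this read-out near its top at the one concentration tested, which is something the earlier compounds, all of which carry that ring, could not show. Nothing measured here explains this result.

With compound 1 and compound 4 both so close to the top of the scale, a single concentration cannot tell whether a real difference in potency lies hidden between them. On these data alone, it also stays open what dimethylamino, which lacks the amide hydrogen, a longer chain such as butylamino, or a carboxylic acid would give on the same carbonyl carbon.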